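A Methoxy-to-Nitro Change Judged From Two Measured Analogues

The source may hold more compounds than are shown below. What is called first, only, known or untested is meant among the compounds shown, and "the series" means these compounds.

Compound 1, `O=C1N=C(N2CCC[C@H]2C(=O)Nc2ccc3ncnc(Nc4cccc(Cl)c4)c3c2)S/C1=C/c1cccnc1`, gives 8500 nM in a functional assay on HepG2 cells (Homo sapiens) for antiproliferative activity, read by MTT assay; a higher number here means a weaker inhibitor, a lower number a stronger inhibitor.
Compound 2, `COc1ccccc1/C=C1/SC(N2CCC[C@H]2C(=O)Nc2ccc3ncnc(Nc4cccc(Cl)c4)c3c2)=NC1=O`, gives 22100 nM in this assay.

Among the two compounds measured, compound 2 has the highest number, meaning it is the weaker of the pair; its only neighbour is compound 1, and the step between them is a 2.6-fold higher number from compound 1 to compound 2 (0.41 log units; beyond the scatter). That step swaps the whole ring hanging from the double-bonded chain carbon, pyridin-3-yl for 2-methoxyphenyl.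

Compound 3, `O=C1N=C(N2CCC[C@H]2C(=O)Nc2ccc3ncnc(Nc4cccc(Cl)c4)c3c2)S/C1=C/c1ccccc1[N+](=O)[O-]`, keeps the phenyl ring of compound 2 and alters one group on it: nitro in place of methoxy on an aromatic carbon. Among the measured compounds shown here, no measured step changes a group on that ring while keeping the ring itself, so the one step in hand, a 2.6-fold higher number from compound 1 to compound 2 (0.41 log units; beyond the scatter), bears on this change only loosely, showing that alterations at this position move the number modestly. The step from compound 2 to compound 3 is therefore expected to be small, a 1.5-fold lower number from compound 2 to compound 3 (0.17 log units; within the scatter), with a slight lean back toward compound 1. Compound 3 is estimated at 15000 nM, within a range of 5000 nM to 45000 nM.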

Compound 3, half-maximal inhibitory concentration: 32500 nM
Compound 3: the middle estimate sits 2.2-fold (0.34 log units) below what was measured, and the stated range covers the measured number.
By their numbers in this assay, from the lowest: compound 1; then compounds 2 and 3 (each within the scatter of the next).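

Nitro in place of methoxy on an aromatic carbon is the first measured change that keeps the phenyl ring and alters only the group on it, and in this assay it gives a 1.5-fold higher number from compound 2 to compound 3 (0.17 log units; within the scatter), so the two groups cannot be told apart here. The pyridin-3-yl ring of compound 1 stands apart from both substituted phenyl rings, with a 3.8-fold higher number from compound 1 to compound 3 (0.58 log units; beyond the scatter) alongside a 2.6-fold higher number from compound 1 to compound 2 (0.41 log units; beyond the scatter), so among these three compounds the steps beyond the scatter are the ones that replace the whole ring, while the one that swaps the group on the phenyl ring is not. Nothing available explains either the small step or the larger ones.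

As far as these compounds go, whether an amine or a carboxylic acid on that same aromatic carbon would also stay level with methoxy and nitro remains open, as does whether a phenyl ring carrying no group at all would fall with compound 2 and compound 3 or nearer to compound 1. It is also unknown whether a methoxy or nitro group added to the pyridin-3-yl ring of compound 1 would keep its lower number.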